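Removing a Methyl from the Pyrazole in a Weak Series

The source may report more compounds than this note shows. Statements on the series, on what has been measured and on what is new or still open speak of the compounds shown alone.

In an assay on membranes from brain for binding affinity to neutral cholesterol ester hydrolase 1 (Mus musculus), read by fluorescence, with stated times of 1 h and 30 min (on this read-out lower numbers stand for stronger inhibition and higher numbers for weaker inhibition), compound 1 `Cc1cnn(C(=O)N2CCCN(Cc3ccc(OCc4ccccc4)cc3)CC2)c1` gives a value that is only a limit of the assay, > 100000 nM. Compound 2 `O=C(N1CCCN(Cc2ccc(OCc3ccccc3)cc2)CC1)n1cccn1`, in this assay, also gives only a limit, > 100000 nM. The change from compound 1 to compound 2 is hydrogen in place of methyl on an aromatic carbon; the step that the two limits leave unreadable from compound 1 to compound 2 cannot be read, because of the limit of > 100000 nM in this assay, at which 3 of the 3 values shown sit. Compound 3 `Cc1cnn(C(=O)NCc2ccc(OC(c3ccccc3)c3ccccc3)cc2)c1` carries a different core, and the difference between the two cores is not broken down here. In this assay compound 3 also gives only a limit, > 100000 nM. Compound 4 `O=C(NCc1ccc(OC(c2ccccc2)c2ccccc2)cc1)n1cccn1` has not yet been measured. It differs from compound 3 by hydrogen in place of methyl on an aromatic carbon, the same change as from compound 1 to compound 2. Because (the limit of > 100000 nM in this assay, at which 3 of the 3 values shown sit), the step from compound 3 to compound 4 is expected to be unreadable too, and my estimate is a step that the limit leaves unreadable from compound 3 to compound 4. For compound 4 in this assay I expect a value of about 150000 nM, most likely again reported only as a limit, between 50000 nM and 500000 nM.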

Compound 4, half-maximal inhibitory concentration: > 100000 nM
Compound 4: no number, only a limit (the forecaster's own chance of this, stated with the estimate: 85%); the middle value does not contradict the limit.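

Compound 4, like compound 3, gives only a limit of the assay, so the step between them cannot be read, because all values sit at one limit: the limit of > 100000 nM in this assay, at which 4 of the 4 values shown sit.

What the compounds shown leave open is whether removing the pyrazole methyl changes inhibition at all, since no compound here gives an actual number in this assay.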